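The compounds below may be only part of what the source reports. "The series", "measured", "known", "first", "only" and "open" are said of these compounds alone.

Measured so far in a functional assay on the whole organism (6C3HED cells, Mus musculus) for inhibition, at a dose of 150 mg/kg by the oral route; a lower number here means less inhibition, a higher number more inhibition at the dose given (going by the name of the read-out):
compound 1 `CSc1ccc(S(=O)(=O)NC(=O)Nc2ccc(Cl)cc2)s1`: 29%
compound 2 `CCCc1ccc(S(=O)(=O)NC(=O)Nc2ccc(Cl)cc2)s1`: 38%
compound 3 `CC(C)c1ccc(S(=O)(=O)NC(=O)Nc2ccc(Cl)cc2)s1`: 42%

Compound 3 stands highest of the three numbers; compound 2 is nearest and compound 1 furthest. Only a number 13 percentage points higher from compound 1 to compound 3 (beyond the scatter) lies beyond the scatter; a number 9 percentage points higher from compound 1 to compound 2 (within the scatter) and a number 4 percentage points higher from compound 2 to compound 3 (within the scatter) do not. Compound 4 `CCCOc1ccc(S(=O)(=O)NC(=O)Nc2ccc(Cl)cc2)s1` is not yet measured. The change is propoxy in place of isopropyl on an aromatic carbon. For the measured compounds named here, the steps that bear on it are a number 13 percentage points higher from compound 1 to compound 3 (beyond the scatter), in which methylsulfanyl at the same place gave the lower number, and a number 4 percentage points higher from compound 2 to compound 3 (within the scatter), in which propyl at the same place gave a number within the scatter of compound 3. From these a small fall in this assay is expected, a number 9 percentage points lower from compound 3 to compound 4 (within the scatter), likely within the scatter. Compound 4 is therefore expected to give 33%, in the range 20% to 46%.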

Compound 4, a percentage reported as inhibition, in the whole organism at one dose (the size of the read-out at that dose, not a potency): 44%
Estimate against measurement, compound 4: 11 percentage points below, and the stated range covers the measured number.
By their numbers in this assay, from the lowest: compounds 1, 2, 3 and 4 (each within the scatter of the next, the first and the last beyond it).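

On the aromatic carbon next to the ring sulfur, propoxy brings a hydrogen-bond acceptor yet stays level with the alkyl groups in this assay (a number 2 percentage points higher from compound 3 to compound 4 (within the scatter); a number 6 percentage points higher from compound 2 to compound 4 (within the scatter)). Methylsulfanyl is separated from propoxy (a number 15 percentage points higher from compound 1 to compound 4 (beyond the scatter)), so the step beyond the scatter seen with isopropyl now has a second example, while propyl still does not separate from methylsulfanyl. Nothing available explains these numbers. From the compounds shown here alone, whether an amine, a carboxylic acid or a chain longer than propoxy at this place would leave this level remains open.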